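Extending an ester in a dihydropyridine series

A few compounds are considered here, and "the series" means these few. Any claim that something is new, unique, unknown or untested is made for them only; others in the source may bear on it.

Measured compounds:
compound 1 `CCOC(=O)C1=C(C)NC(CCl)=C(C(=O)OCC)C1c1cccc([N+](=O)[O-])c1`: 53 nM
compound 2 `C=CCOC(=O)C1=C(C)NC(C)=C(C(=O)OC)C1c1ccccc1[N+](=O)[O-]`: 10 nM
compound 3 `C=CCOC(=O)C1=C(C)NC(C)=C(C(=O)OC)C1c1cccc([N+](=O)[O-])c1`: 15 nM

Of the compounds shown here, three have been tested in a functional assay on HEK293 cells for antagonist activity at Voltage-dependent L-type calcium channel subunit alpha-1D (Rattus norvegicus), read by FLIPR; a lower number here means a stronger inhibitor, a higher number a weaker inhibitor. Compound 1 gives 53 nM in this assay, compound 2 gives 10 nM, and compound 3 gives 15 nM. Compound 3 stands second highest of the three; its nearest neighbour is compound 2, and the furthest is compound 1. Going by the values given here, the one step between compounds differing in a single place, a 1.5-fold higher number from compound 2 to compound 3 (0.18 log units; within the scatter), lies within the scatter.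

Compound 4 `COC(=O)C1=C(C)NC(C)=C(C(=O)OCCc2ccc(Cl)cc2)C1c1cccc([N+](=O)[O-])c1` has not yet been measured. It differs from compound 3 in the ester: 4-chlorobenzyl in place of vinyl on a saturated chain carbon bound to an oxygen next to a carbonyl group

Among the compounds with values here, no measured step concerns a change at this ester. Within the data shown here, the only step, a 1.5-fold higher number from compound 2 to compound 3 (0.18 log units; within the scatter), alters the aryl group and not the ester, so it offers no guide to the size or direction of the present change. With nothing to rest on beyond the closeness of compound 3 to compound 2 and compound 1, the expected step of a 1.3-fold higher number from compound 3 to compound 4 (0.12 log units; within the scatter) for compound 4 is none beyond the scatter, though with wide uncertainty. Compound 4 is therefore estimated at 20 nM, within a range from 5 nM to 80 nM.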

Compound 4, half-maximal inhibitory concentration: 39 nM
Beside the measured number, compound 4's estimate is 2.0-fold (0.29 log units) below it; low and high end bracket the measured number.
By their numbers in this assay, from the lowest: compounds 2 and 3 (each within the scatter of the next); then compounds 4 and 1 (each within the scatter of the next).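

Going by these compounds alone, at this ester, 2-(4-chlorophenyl)ethyl in place of allyl gives a 2.6-fold higher number from compound 3 to compound 4 (0.41 log units; beyond the scatter) in this assay, the first measured change here and, unlike the change of aryl group, one that lies beyond the scatter. The step remains modest: with 8 heavy atoms and an aromatic ring entering where 2 heavy atoms leave in the vinyl-to-4-chlorobenzyl change, compound 4 still gives 39 nM, so this position accepts a much larger group on the shared core. No measurement shown explains the step.

Still open, from the compounds shown here alone, is which part of the new group carries the step: a 2-phenylethyl ester would isolate the chlorine, and a plain butyl ester the aromatic ring. Also open, going by these compounds, is whether an ester ending in an amine would fit this position, and whether the step holds with 2-nitrophenyl as the aryl group.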